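The source may hold more compounds than are shown below. What is called first, only, known or untested is meant among the compounds shown, and "the series" means these compounds.

Compound 1, `O=C(NO)c1ccc(-c2cn([C@@H]3C[C@@H](C(=O)O)N(Cc4ccccc4)C3)nn2)cc1`: < 10%
Compound 2, `O=C(NO)c1ccc(-c2cn([C@@H]3C[C@@H](CO)N(Cc4ccccc4)C3)nn2)cc1`: < 10%
Compound 3, `O=C(NO)c1ccc(-c2cn([C@@H]3C[C@@H](CO)N(CCCc4ccccc4)C3)nn2)cc1`: 14%

In an assay on Sf9 cells for inhibition of histone deacetylase 11 (Homo sapiens), read by fluorescence, tested at 0.5 uM (on this read-out lower numbers stand for less inhibition and higher numbers for more inhibition at the one concentration tested (going by the name of the read-out)), compound 1 gives only a limit of the assay, < 10%. Compound 2 likewise gives only a limit, < 10%. Compound 3 gives a number, 14%, the only one among the three, as the limit of < 10% in this assay, at which 2 of the 3 values shown sit, shows. Compound 1 differs from compound 2 by carboxy in place of hydroxymethyl on a saturated ring carbon, and the step that the two limits leave unreadable from compound 2 to compound 1. The cores of compound 2 and compound 3 differ by phenethyl in place of phenyl on a saturated chain carbon bound to an amine nitrogen in a ring, and the step of a number at least 4 percentage points higher from compound 2 to compound 3 (that floor lies within the scatter). Compound 4, `O=C(NO)c1ccc(-c2cn([C@@H]3C[C@@H](C(=O)O)N(CCCc4ccccc4)C3)nn2)cc1`, is not yet measured; it differs from compound 3 by carboxy in place of hydroxymethyl on a saturated ring carbon, the same kind of change as that from compound 2 to compound 1, though here the ring atom bears a 3-phenylpropyl group rather than a benzyl group. Compound 4 is expected to give 10%, between 2% and 20%. The expected step is a number 4 percentage points lower from compound 3 to compound 4 (within the scatter), estimated because compound 1 gives only the limit < 10%.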

Compound 4, a percentage reported as inhibition, at one concentration (the size of the read-out at that concentration, not a potency): 14%
For compound 4 the middle estimate is 4 percentage points below the measured one, within the range that was stated.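

Carrying carboxy in place of hydroxymethyl on a saturated ring carbon over to the core of compound 3 gives no change at the digits printed from compound 3 to compound 4 (within the scatter) in this assay. The change from phenyl to phenethyl on the saturated chain carbon gives a number at least 4 percentage points higher from compound 1 to compound 4 (that floor lies within the scatter), and it now stands on two cores: the same change on two cores in this assay, a number at least 4 percentage points higher (that floor lies within the scatter) from compound 2 to compound 3 and a number at least 4 percentage points higher (that floor lies within the scatter) from compound 1 to compound 4; the limit leaves it open whether they differ. This shows no step beyond the scatter for either change, but it does not show that either change carries over with the same size, and the step from compound 2 to compound 1 cannot be read.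

The compounds shown leave open what an amine or an amide on that saturated ring carbon would give in this assay. They also leave open what a chain longer than 3-phenylpropyl on the ring atom would give.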